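The compounds below may be only part of what the source reports. "The series", "measured", "known", "first", "only" and "open" are said of these compounds alone.

Among the three measured compounds, compound 2 `Cc1ccc(S(=O)(=O)n2cc(-c3cc(C(F)(F)F)ccn3)c3cc(Br)ccc32)cc1` gives the highest number in a functional assay on P388 cells (Mus musculus) for inhibition, tested at 100 uM (on this read-out lower numbers stand for a weaker effect and higher numbers for a stronger effect at the one concentration tested), with compound 2 reaching 32.6%. Compound 1 `Cc1ccc(S(=O)(=O)n2cc(-c3cc(C(F)(F)F)c(C#N)c(-c4cn(S(=O)(=O)c5ccc(C)cc5)c5ccc(Br)cc45)n3)c3cc(Br)ccc32)cc1` gives 8.2%, and compound 3 `Cc1ccc(S(=O)(=O)n2cc(-c3cc(C(F)(F)F)cc(-c4cn(S(=O)(=O)c5ccc(C)cc5)c5cc(Br)ccc45)n3)c3ccc(Br)cc32)cc1` gives 8.9%; both lie more than the scatter below compound 2. Compound 4 `Cc1ccc(S(=O)(=O)n2cc(-c3cc(C(F)(F)F)ccn3)c3cc(OCc4ccccc4)ccc32)cc1` has not been measured. It differs from compound 2 in one place: benzyloxy in place of bromo on an aromatic carbon. Compounds 1 and 3 differ from compound 2 in other ways and do not show how this change acts. No direction can be read from the measured numbers, and the expected step of a number 2.6 percentage points lower from compound 2 to compound 4 (within the scatter) is small, not beyond the scatter. Compound 4 is estimated to give 30% in this assay, with a range from 10% to 55%.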

Compound 4, a percentage reported as inhibition, at one concentration (the size of the read-out at that concentration, not a potency): 2.2%
Compound 4: middle estimate off by 27.8 percentage points, on the high side; measured number outside the range, below it.
By their numbers in this assay, from the lowest: compounds 4, 1 and 3 (each within the scatter of the next); then compound 2.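

In this assay, within the data shown here, the change of bromo to benzyloxy on this aromatic carbon gives a number 30.4 percentage points lower from compound 2 to compound 4 (beyond the scatter) and is the first change at a single place that can be read. It shows that the read-out responds to the group at this position, with bromo retaining more inhibition than benzyloxy. Nothing shown accounts for this step. The compounds shown leave open whether the drop belongs to the oxygen, the added aromatic ring or the removal of bromo. They also leave open how a methoxy group, a hydroxyl group or an amine would read at this carbon.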